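The compounds below may be only part of what the source reports. "The series", "measured", "known", "first", "only" and "open" are said of these compounds alone.

Compound 1 (`COc1ccccc1-c1n[nH]cc1N1CCNCC1`): in an assay on isolated protein for binding affinity to 5-hydroxytryptamine receptor 3A (Homo sapiens) (a higher number here means a weaker inhibitor, a lower number a stronger inhibitor), compound 1 gives > 10000 nM, which is a limit of the assay and not a number.
Compound 2 (`COc1ccc(-c2n[nH]cc2N2CCNCC2)cc1`): in this assay compound 2 gives > 10000 nM, again a limit of the assay.
Compound 3 (`Clc1cccc(-c2n[nH]cc2N2CCNCC2)c1`): in this assay compound 3 gives 806 nM.

For the measured compounds named here, all three compounds share the same core and differ only in the single group carried on the six-membered aromatic ring of carbon only. Compound 2 stands at the edge of what the assay can report: no number is known for it, and it shares that position with one other value, (the limit of > 10000 nM in this assay, at which 2 of the 3 values shown sit). Going by the values given here, compound 3 is the only compound with a measured number.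

Compound 4 (`Cc1ccc(-c2n[nH]cc2N2CCNCC2)cc1`) differs from compound 2 by methyl in place of methoxy on an aromatic carbon, a methyl in place of methoxy on an aromatic carbon, para to a large group. Among the compounds with values here, no pair of measured compounds differs in this way, so the size of this change is untested. The step is nevertheless expected to be an at least 2.0-fold lower number from compound 2 to compound 4 (0.30 log units; that floor lies within the scatter), moving compound 4 toward a measurable but still weak value, because compound 3 gives 806 nM and shows that a small group on this ring can yield a number. For compound 4 the expected value in this assay is 5000 nM, with a range from 1500 nM to 20000 nM.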

Compound 4, inhibition constant: > 10000 nM
Compound 4 was reported as a limit; the forecaster's own chance of this, stated with the estimate: 40%; middle value at least 2.0-fold (0.30 log units) from the limit.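

Compound 2 and compound 4 both sit at the same limit of the assay, so the step between them cannot be read and the swap of methoxy for methyl has no size: the limit of > 10000 nM in this assay, at which 3 of the 4 values shown sit.

The compounds shown leave open what actual number either compound would give in this assay, and so whether methoxy and methyl at this place differ at all.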